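Redrawn Stereocentres and an Unchanged Inhibition Readout

The source may report more compounds than this note shows. Statements on the series, on what has been measured and on what is new or still open speak of the compounds shown alone.

Three compounds share one set of atoms and bonds and differ only in how their two ring stereocentres are drawn. Compound 1 `C[C@]1(CO)OC[C@@H](n2ccc(N)nc2=O)O1` gives 100000 nM in a functional assay on B16-F10 cells (Mus musculus) for inhibition; a lower number here means a stronger inhibitor, a higher number a weaker inhibitor. Compound 2 `CC1(CO)OCC(n2ccc(N)nc2=O)O1` gives 100000 nM in this assay, and compound 3 `C[C@]1(CO)OCC(n2ccc(N)nc2=O)O1` gives 100000 nM in the same assay. Compound 3 thus stands level with both of its partners, nearest to compound 1 and furthest from compound 2, although neither gap rises above the scatter.

Compound 4 `CC1(CO)OC[C@@H](n2ccc(N)nc2=O)O1` is the next variant of this set. Relative to compound 3 the change is the two compounds have the same atoms and bonds; at least one stereo element is drawn with a configuration in one of them and without one in the other: 2 of 2 stereo elements differ; a stereocentre at a saturated ring carbon is drawn S in compound 3 and without a configuration in compound 4; a stereocentre at a saturated ring carbon is drawn without a configuration in compound 3 and S in compound 4. The measured steps that bear on it are all of one kind: no change at the digits printed from compound 1 to compound 2 (within the scatter), no change at the digits printed from compound 1 to compound 3 (within the scatter) and no change at the digits printed from compound 2 to compound 3 (within the scatter), each of them resting on a difference in drawn configuration at one or both ring carbons the fact that one of compounds 1 and 2 is drawn with a defined configuration and the other without, at the place where they differ the fact that one of compounds 1 and 3 is drawn with a defined configuration and the other without, at the place where they differ (the fact that one of compounds 2 and 3 is drawn with a defined configuration and the other without, at the place where they differ). None of these steps moved the readout. One therefore expects no step beyond the scatter in this assay, in either direction, when going to compound 4, that is no change at the digits printed from compound 3 to compound 4 (within the scatter). Compound 4 is estimated at 100000 nM, with an expected range from 50000 nM to 200000 nM.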

Compound 4, half-maximal inhibitory concentration: > 100000 nM
Compound 4 gave a limit, no number; the forecaster's own chance of this, stated with the estimate: 60%; the middle value sits exactly at the limit.
By their numbers in this assay, from the lowest: compounds 1, 2 and 3 (each within the scatter of the next).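

Compound 4 gives > 100000 nM in this assay, and this value is a limit of the assay, not a number. Among the compounds shown here, compound 4 is the first of the set to give a limit rather than a printed number, and it shows that moving the single drawn S configuration from one ring carbon to the other does not bring a value lower than those of the earlier compounds. The set shows a number no lower from compound 3 to compound 4 (the limit leaves the size open) and a number no lower from compound 2 to compound 4 (the limit leaves the size open) and also a number no lower from compound 1 to compound 4 (the limit leaves the size open) and none of these steps can be read in size, so the set still offers no measured difference that can be tied to drawn configuration, and the reading for compound 4 rests on this: the limit of > 100000 nM in this assay, at which 1 of the 4 values shown sits.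

The compounds shown leave open how far compound 4 lies from the other three, and whether a stereocentre drawn R at either ring carbon would give a readable value in this assay. They also leave open whether a carboxylic acid or a longer chain in place of the hydroxymethyl group on the shared core would give a value clear of the scatter around these results.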